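The compounds below may be only part of what the source reports. "The series", "measured", "known", "first", "only" and "open" are said of these compounds alone.

Compound 1 `CO[C@@H](C(=O)N[C@@H]1CCCCNC1=O)[C@H](O)[C@@H](O)[C@H](O)/C=C/C(C)(C)C` gives 2100 nM in a functional assay on HeLa cells (Homo sapiens) for cytotoxicity, read by colorimetric assay and neutral red uptake, with a stated time of 72 h; on this read-out lower numbers stand for stronger inhibition and higher numbers for weaker inhibition. Compound 2 `CO[C@@H](C(=O)N[C@H]1CC[C@H](O)CNC1=O)[C@H](O)[C@@H](O)[C@H](O)/C=C/C(C)(C)C` is reported in this assay only as the limit > 150000 nM, not as a number. Among the measured compounds shown here, the one measured step is an at least 71-fold higher number from compound 1 to compound 2 (1.85 log units; beyond the scatter), and it ends at the limit (the limit of > 150000 nM in this assay, at which 1 of the 2 values shown sits). Compound 3 `CO[C@@H](C(=O)N[C@@H]1CC[C@@H](O)CNC1=O)[C@H](O)[C@@H](O)[C@H](O)/C=C/C(C)(C)C` has the same atoms and bonds as compound 2 and differs only in configuration as drawn: the two compounds have the same atoms and bonds and differ only in configuration as drawn: 2 of 7 stereo elements differ; a stereocentre at a saturated ring carbon is drawn S in compound 2 and R in compound 3; a stereocentre at a saturated ring carbon is drawn S in compound 2 and R in compound 3. For the measured compounds named here, no measured step concerns a change of configuration alone, so the direction of the step from compound 2 to compound 3 in this assay is open; both a stay at the limit and a partial return toward the number of compound 1 are possible. The step is expected as an at least 1.5-fold lower number from compound 2 to compound 3 (0.17 log units; that floor lies within the scatter). Compound 3 is therefore estimated at 100000 nM, between 15000 nM and 300000 nM.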

Compound 3, half-maximal inhibitory concentration: 15400 nM
Compound 3: middle estimate off by 6.5-fold (0.81 log units), on the high side, and the stated range covers the measured number.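

Configuration alone separates the two hydroxy compounds in this assay, with an at least 9.7-fold lower number from compound 2 to compound 3 (0.98 log units; beyond the scatter): the fact that compounds 2 and 3 differ only in the configuration as drawn. Compound 2 stands only at a limit of the assay, so that step has a floor and no exact size: the limit of > 150000 nM in this assay, at which 1 of the 3 values shown sits. Even in compound 3, hydroxy in place of hydrogen on a saturated ring carbon gives a higher number, with a 7.3-fold higher number from compound 1 to compound 3 (0.87 log units; beyond the scatter), but the number stays clear of the limit.

Which of the changed stereocentres carries the step stays open. As far as these compounds go, whether an amine or a methoxy group in place of the hydroxy would follow the same pattern also stays open.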